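Ring Change at the Amide of Compound 3

A few compounds are considered here, and "the series" means these few. Any claim that something is new, unique, unknown or untested is made for them only; others in the source may bear on it.

Compound 1 `COc1ccc2c(c1)CCCC2NC(=O)C[C@@H]1C(=O)NC=CN1S(=O)(=O)c1ccc(C)cc1` gives 8.95 nM in an in vitro functional assay on cells for antagonist activity at B1 bradykinin receptor (Homo sapiens), read by luminescence and calcium flux, with a stated time of 2 h; on this read-out higher numbers stand for weaker inhibition and lower numbers for stronger inhibition.
Compound 2 `CCN1CC[C@H](NC(=O)C[C@@H]2C(=O)NC=CN2S(=O)(=O)c2ccc(C)cc2)C(C)(C)C1` gives 0.63 nM in this assay.
Compound 3 `Cc1cc(S(=O)(=O)N2C=CNC(=O)[C@H]2CC(=O)N2CC[C@H](N3CCCC3)C2)c(C)cc1Cl` gives 19 nM in this assay.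

Compound 3 gives the highest of these three numbers; compound 1 stands nearest and compound 2 furthest, and both gaps lie beyond the scatter. Compound 4 `Cc1cc(S(=O)(=O)N2C=CNC(=O)[C@H]2CC(=O)N2CCCCC(N(C)C)CC2)c(C)cc1Cl` differs from compound 3 by a group of 11 heavy atoms (9 carbon, 2 nitrogen; one eight-membered non-aromatic ring with 1 hetero atom) in place of a group of 10 heavy atoms (8 carbon, 2 nitrogen; 2 five-membered non-aromatic rings with 1 hetero atom each), on a carbonyl carbon. For the measured compounds named here, no pair of measured compounds shows a change of this kind, so the expectation rests on the spread of the three numbers alone. A modest move toward a higher number in this assay is expected, a 1.8-fold higher number from compound 3 to compound 4 (0.27 log units; within the scatter), though a step within the scatter would not surprise. Compound 4 is therefore expected at 35 nM, with a range from 9 nM to 140 nM.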

Compound 4, half-maximal inhibitory concentration: 4.75 nM
Compound 4: middle estimate off by 7.4-fold (0.87 log units), on the high side; the measured number lies below the stated range.
By their numbers in this assay, from the lowest: compound 2; then compounds 4 and 1 (each within the scatter of the next); then compound 3.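

In this assay, putting the group with one eight-membered non-aromatic ring with 1 hetero atom in place of the group with 2 five-membered non-aromatic rings with 1 hetero atom each, on a carbonyl carbon, gives the first step read at this place (a 4.0-fold lower number from compound 3 to compound 4 (0.60 log units; beyond the scatter)). The step shows that this place accepts the larger single-ring group with a lower number, not a higher one. Nothing measured here accounts for the step. On these data alone, it remains open whether the ring size or the amine on the ring carries this step, and whether a carboxylic acid there would keep the number this low.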